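Shortening the Linker Chain of a Weak Retinoid-Type Ester

The compounds below may be only part of what the source reports. "The series", "measured", "known", "first", "only" and "open" are said of these compounds alone.

Measured compounds:
compound 1, `Cc1cc2c(cc1C(=O)c1ccc(C(=O)OCCCOC(=O)c3ccc(C(=O)Nc4ccc5c(c4)C(C)(C)CCC5(C)C)cc3)cc1)C(C)(C)CCC2(C)C`, 14900 nM
compound 2, `CCCC(CCC)C(=O)OCCCCOC(=O)c1ccc(C(=O)Nc2ccc3c(c2)C(C)(C)CCC3(C)C)cc1`, 914000 nM

Of the compounds shown here, two have been measured in a functional assay on HL-60 cells (Homo sapiens) for inhibition, read by MTT assay, with a stated time of 48 h; a higher number here means a weaker inhibitor, a lower number a stronger inhibitor. Compound 1 gives 14900 nM, while compound 2 gives 914000 nM. Compound 2 therefore stands at the higher of the two numbers, the weaker of the pair, and its distance from compound 1 lies well beyond the scatter of the assay. Among the compounds with values here, the two structures differ in more than one place, so no single step between them is described here.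

Compound 3, `CCCC(CCC)C(=O)OCCOC(=O)c1ccc(C(=O)Nc2ccc3c(c2)C(C)(C)CCC3(C)C)cc1`, has not yet been measured. It differs from compound 2 in one place: ((1-propylbutyl)carbonyl)oxy in place of 2-(((1-propylbutyl)carbonyl)oxy)ethyl on a saturated chain carbon, two bonds along the chain from an oxygen next to a carbonyl group. The chain joining the two ester groups is thereby shortened, and the rest of the molecule is kept.

Because compound 2 gives 914000 nM, a very high number, the expected step is small and is not expected to go beyond the scatter: a 1.1-fold lower number from compound 2 to compound 3 (0.06 log units; within the scatter). Compound 3 is expected to give about 800000 nM, in a range from 300000 nM to 2500000 nM.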

Compound 3, half-maximal inhibitory concentration: 256000 nM
The estimate for compound 3 lay 3.1-fold (0.49 log units) above the measured number; measured number below the stated range.
By their numbers in this assay, from the lowest: compound 1; then compound 3; then compound 2.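

In this assay, shortening the chain that joins the two ester groups does have a measurable effect (a 3.6-fold lower number from compound 2 to compound 3 (0.55 log units; beyond the scatter)), a modest step but one beyond the scatter. Compounds 1 and 2 differ in more than one place, so they could not show that this position, on a saturated chain carbon, two bonds along the chain from an oxygen next to a carbonyl group, responds to a change on its own: with 2-(((1-propylbutyl)carbonyl)oxy)ethyl giving way to ((1-propylbutyl)carbonyl)oxy, and the rest of the molecule kept, compound 3 is the stronger inhibitor of this pair, though both remain weak by the numbers in this assay. No measurement at hand accounts for this step, so the reason for it stays unknown.

Within the data shown here, a single shortening gives only one step, so it remains open whether the trend would continue with a still shorter chain or reverse with a longer chain than that of compound 2. It is also unknown how this position would respond if the terminal ester were replaced by a different group, such as a carboxylic acid or an amine.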